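The compounds below may be only part of what the source reports. "The series", "measured", "known", "first", "only" and "open" are said of these compounds alone.

Measured compounds:
compound 1 `NCCOc1cc(-c2cccnc2)ccc1C(N)=O` — 820 nM in an assay on cells for inhibition of MAP kinase-interacting serine/threonine-protein kinase 1 (Homo sapiens), read by mobility shift assay, with stated times of 10 min and 60 min, in the presence of a further agent that is not named here; on this read-out higher numbers stand for weaker inhibition and lower numbers for stronger inhibition
compound 2 `NC(=O)c1ccc(-c2cccnc2)cc1Cl` — 11000 nM in this assay
compound 3 `NC(=O)c1ccc(-c2cccnc2)cc1OC1CCCCC1` — 1500 nM in this assay

Compound 3 stands second highest of the three; against compound 1 the gap is a 1.8-fold higher number from compound 1 to compound 3 (0.26 log units; within the scatter), within the scatter, while against compound 2 it is a 7.3-fold lower number from compound 2 to compound 3 (0.87 log units; beyond the scatter), beyond it. Compound 4 `CC(C)Oc1cc(-c2cccnc2)ccc1C(N)=O` differs from compound 3 by isopropyl in place of cyclohexyl on an oxygen on an aromatic ring. Going by the values given here, two measured steps bear on this: the exchange of one group on the ring oxygen, a 1.8-fold higher number from compound 1 to compound 3 (0.26 log units; within the scatter), which stayed within the scatter, and the change away from chloro, a 7.3-fold lower number from compound 2 to compound 3 (0.87 log units; beyond the scatter), which was modest. Since the oxygen is kept and only its alkyl group shrinks, no step beyond the scatter is expected in this assay. The expected step is a 1.1-fold lower number from compound 3 to compound 4 (0.03 log units; within the scatter). Compound 4 is estimated at 1400 nM, with a range from 500 nM to 4000 nM.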

Compound 4, half-maximal inhibitory concentration: 880 nM
Compound 4: the middle estimate sits 1.6-fold (0.20 log units) above what was measured; low and high end bracket the measured number.
By their numbers in this assay, from the lowest: compounds 1, 4 and 3 (each within the scatter of the next); then compound 2.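

On the oxygen on an aromatic ring, isopropyl replaces cyclohexyl with a 1.7-fold lower number from compound 3 to compound 4 (0.23 log units; within the scatter) and replaces 2-aminoethyl with a 1.1-fold higher number from compound 1 to compound 4 (0.03 log units; within the scatter) so these three groups on the oxygen cannot be told apart here. A ring on the oxygen is therefore not needed to hold the number, and isopropoxy in place of chloro still gives a 13-fold lower number from compound 2 to compound 4 (1.10 log units; beyond the scatter) as a large step. No measured evidence accounts for these results.

On these data alone, whether the oxygen itself is needed remains open, as a directly attached amine would test. Methoxy, a hydroxyl group or a longer chain ending in a carboxylic acid could also show how far this position extends.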